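The source may report more compounds than this note shows. Statements on the series, on what has been measured and on what is new or still open speak of the compounds shown alone.

Compound 1 `CN(C)CCn1cnnc1-c1cc(Oc2ccc(NC(=O)N/N=C/c3ccc(Cl)cc3Cl)cc2F)ccn1` gives 390 nM in a functional assay on HT-29 cells (Homo sapiens) for cytotoxicity, read by MTT assay, with a stated time of 72 h (on this read-out lower numbers stand for stronger inhibition and higher numbers for weaker inhibition), the highest of the three numbers recorded there. Compound 2 `CN(C)CCn1cnnc1-c1cc(Oc2ccc(NC(=O)N/N=C/c3cccc(Cl)c3Cl)cc2F)ccn1` gives 130 nM, and compound 3 `CN(C)CCn1cnnc1-c1cc(Oc2ccc(NC(=O)N/N=C/c3cccc(Br)c3)cc2F)ccn1` gives 380 nM; the step of a 3.0-fold lower number from compound 1 to compound 2 (0.48 log units; beyond the scatter) lies beyond the scatter, whereas the step of a 1.0-fold lower number from compound 1 to compound 3 (0.01 log units; within the scatter) does not. Compound 4 `CN(C)CCn1cnnc1-c1cc(Oc2ccc(NC(=O)N/N=C/c3ccc(Cl)cc3)cc2F)ccn1` differs from compound 1 by hydrogen in place of chloro on an aromatic carbon. Among the measured compounds shown here, no measured step removes a chloro group, so none bears on it directly; the two steps from compound 1 only show that changes on this ring move the number by a modest amount at most, in either direction. A step within the scatter, or a slightly higher number, is therefore expected for compound 4, a 1.3-fold higher number from compound 1 to compound 4 (0.11 log units; within the scatter). Compound 4 is accordingly estimated at 500 nM, with a range from 200 nM to 1200 nM.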

Compound 4, half-maximal inhibitory concentration: 530 nM
For compound 4 the middle estimate is 1.1-fold (0.03 log units) below the measured one; the range from low to high includes it.
By their numbers in this assay, from the lowest: compound 2; then compounds 3, 1 and 4 (each within the scatter of the next).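

In this assay, hydrogen in place of chloro stays within the scatter (a 1.4-fold higher number from compound 1 to compound 4 (0.13 log units; within the scatter)), so the 2,4-dichlorophenyl and 4-chlorophenyl groups are not told apart here. The 4-chlorophenyl and 3-bromophenyl groups are likewise not told apart (a 1.4-fold higher number from compound 3 to compound 4 (0.14 log units; within the scatter)), while 2,3-dichlorophenyl alone stands clear of 4-chlorophenyl (a 4.1-fold higher number from compound 2 to compound 4 (0.61 log units; beyond the scatter)). Nothing given here explains these numbers. The compounds shown leave open whether 2,3-dichlorophenyl stands apart only with two halogens on the ring, and how an amine or a methoxy group on this ring would compare.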